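Shaking up the side chain on a shared quinone core

This account rests on a few compounds, and the source may have more. Where it says the series, first, only, none or still open, it means among the compounds named here.

Measured so far:
compound 1, `CC(C)=CC[C@@H](OC(=O)c1ccco1)C1=CC(=O)c2c(O)ccc(O)c2C1=O`: 80300 nM
compound 2, `COCCO[C@H](CC=C(C)C)C1=CC(=O)c2c(O)ccc(O)c2C1=O`: 62400 nM

In a functional assay on HeLa cells (Homo sapiens) for cytotoxicity, read by MTT assay (a higher number here means a weaker inhibitor, a lower number a stronger inhibitor), compound 2 gives the lower of the two numbers shown, yet the gap to compound 1 is small: a 1.3-fold lower number from compound 1 to compound 2 (0.11 log units; within the scatter). So far, swapping a (furan-2-yl)carbonyl for a 2-methoxyethyl on the oxygen on the saturated carbon has not moved the read-out beyond the scatter.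

Compound 3, `CCCC(C)(O)CC(=O)O[C@H](CC=C(C)C)C1=CC(=O)c2c(O)ccc(O)c2C1=O`, changes that same position once more: (2-hydroxy-2-methylpentyl)carbonyl in place of 2-methoxyethyl on an oxygen on a saturated carbon. Among the compounds with values here, the only measured step that bears on this is the one from compound 1 to compound 2, and it was within the scatter. Compound 3 returns to an ester, as in compound 1, but with a longer, hydroxyl-bearing chain rather than a ring. Nothing seen so far suggests that this oxygen substituent drives the number strongly either way, so the expected step of a 1.1-fold higher number from compound 2 to compound 3 (0.05 log units; within the scatter) is small, with a slight lean back toward the number of compound 1.

Compound 3 is therefore expected to give about 70000 nM in this assay, with a likely range of 30000 nM to 160000 nM.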

Compound 3, half-maximal inhibitory concentration: 72000 nM
The estimate for compound 3 lay 1.0-fold (0.01 log units) below the measured number; low and high end bracket the measured number.
By their numbers in this assay, from the lowest: compounds 2, 3 and 1 (each within the scatter of the next).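

In this assay, the ester chain of compound 3 leaves the read-out in the same place as both earlier groups: the change of ester for 2-methoxyethyl gives a 1.2-fold higher number from compound 2 to compound 3 (0.06 log units; within the scatter) and the swap between the two esters gives a 1.1-fold lower number from compound 1 to compound 3 (0.05 log units; within the scatter) as its result. Within the data shown here, the earlier pair offered only one comparison at this oxygen, whereas these two steps add that neither 9 heavy atoms in place of 4 nor an open chain carrying a hydrogen-bond donor in place of the furan-2-yl ring moves the number beyond the scatter. No measurement available here gives a reason for this flat picture.

All three groups shown are neutral and attached through the same oxygen, so it remains open whether an amine, a carboxylic acid or a simple hydrogen on that oxygen would shift the number. The compounds also leave open whether changes elsewhere on the shared core would matter more than changes at this position.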